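The compounds below may be only part of what the source reports. "The series", "measured", "known", "first", "only" and "open" are said of these compounds alone.

Measured compounds, inhibition in an assay on HEK293 cells for inhibition of Voltage-dependent T-type calcium channel subunit alpha-1G (Homo sapiens), read by fluorescence, tested at 10 uM; on this read-out higher numbers stand for more inhibition at the one concentration tested (going by the name of the read-out) and lower numbers for less inhibition:
- compound 1, `CCCc1nc(-c2ccccc2)c(CNCCCN2CCN(c3ccc(F)cc3)CC2)o1`: 62.5%
- compound 2, `CCCc1nc(-c2ccccc2)c(CNCCN2CCN(c3ccccc3F)CC2)o1`: 46.5%
- compound 3, `CCCc1nc(-c2ccccc2)c(CNCCCN2CCN(c3cccc(C(F)(F)F)c3)CC2)o1`: 51.6%

Compound 2 has the lowest of the three numbers; its nearest neighbour is compound 3, within the scatter, while compound 1 lies beyond the scatter above it. Among the measured compounds shown here, compound 2 also carries a shorter chain between the secondary amine and the ring nitrogen than compounds 1 and 3; no step for that pair is given, so only the two values themselves can be set side by side.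

Compound 4, `CCCc1nc(-c2ccccc2)c(CNCCN2CCN(c3cccc(F)c3)CC2)o1`, differs from compound 2 by 3-fluorophenyl in place of 2-fluorophenyl on an amine nitrogen in a ring. For the measured compounds named here, the only measured step on the aryl group on the ring nitrogen is a number 10.9 percentage points lower from compound 1 to compound 3 (beyond the scatter), and it changes both the substituent and where it sits, so it bears on the present step only loosely. Moving a single fluorine from 2-fluorophenyl to 3-fluorophenyl is expected to give no step beyond the scatter, a number 3.5 percentage points higher from compound 2 to compound 4 (within the scatter). Compound 4 is therefore expected to give about 50% in this assay, within a range of 36% to 64%.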

Compound 4, a percentage reported as inhibition, at one concentration (the size of the read-out at that concentration, not a potency): 62.3%
Compound 4: middle estimate off by 12.3 percentage points, on the low side; measured number inside the range.
By their numbers in this assay, from the lowest: compounds 2 and 3 (each within the scatter of the next); then compounds 4 and 1 (each within the scatter of the next).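

In this assay, moving one fluorine on the aryl group gives a number 15.8 percentage points higher from compound 2 to compound 4 (beyond the scatter) while the chain, the shared core and the counted atoms of the group stay the same. Among the compounds shown here, the only earlier step on this group changed the substituent and its place together, whereas this one isolates place and shows that 3-fluorophenyl and 2-fluorophenyl on the ring nitrogen are not interchangeable. No measurement at hand bears on the origin of this step.

The compounds shown leave open how 4-fluorophenyl, unsubstituted phenyl or 3-chlorophenyl would read on the chain of compounds 2 and 4. They also leave open whether moving the fluorine gives a similar step on the longer propyl-type chain of compounds 1 and 3.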